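Methoxy to fluoro on the pendant phenyl of compound 1

The source may hold more compounds than are shown below. What is called first, only, known or untested is meant among the compounds shown, and "the series" means these compounds.

In an assay on isolated protein for agonist activity at Free fatty acid receptor 1 (Homo sapiens) (a higher number here means that more compound is needed for the effect, a lower number that less compound is needed), compound 1 `CC#CC(CC(=O)O)c1ccc(OCc2ccc3nc(-c4ccc(OC)cc4)cn3c2)cc1` gives 47 nM, the lowest of the three numbers recorded. Compound 2 `CC#CC(CC(=O)O)c1ccc(OCc2ccn3cc(-c4ccc(CC)cc4)nc3c2)cc1` gives 671 nM in this assay, and compound 3 `CC#CC(CC(=O)O)c1ccc(OCc2ccn3cc(-c4cccc(C)c4)nc3c2)cc1` gives 1510 nM; both stand well above compound 1 and also differ from it in the core, so their gap to compound 1 cannot be assigned to the aryl substituent alone. Among the compounds with values here, the only single-point step available, a 2.3-fold higher number from compound 2 to compound 3 (0.35 log units; beyond the scatter), is a modest one and concerns a different exchange on a different core.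

Compound 4 `CC#CC(CC(=O)O)c1ccc(OCc2ccc3nc(-c4ccc(F)cc4)cn3c2)cc1` is compound 1 with fluoro in place of methoxy on an aromatic carbon; read one bond further out, this is 4-methoxyphenyl to 4-fluorophenyl, the group sitting para to a large group. Within the data shown here, no measured pair shows this exchange, and the step between compound 2 and compound 3 only indicates that a change of the substituent on that phenyl moves this assay by a modest amount. On that basis a small loss is expected for compound 4, a 1.9-fold higher number from compound 1 to compound 4 (0.28 log units; within the scatter), in this assay. Compound 4 is therefore estimated at 90 nM in this assay, with a range of 35 nM to 250 nM.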

Compound 4, half-maximal effective concentration: 623 nM
The estimate for compound 4 lay 6.9-fold (0.84 log units) below the measured number, outside the stated range (above it).
By their numbers in this assay, from the lowest: compound 1; then compounds 4 and 2 (each within the scatter of the next); then compound 3.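

In this assay, the group para to a large group on the pendant phenyl of compound 1 turns out to matter strongly: fluoro in place of methoxy gives a 13-fold higher number from compound 1 to compound 4 (1.12 log units; beyond the scatter) on the shared core. Within the data shown here, this is the first exchange read at this position on this core, and it is a large step, whereas the only earlier step, a 2.3-fold higher number from compound 2 to compound 3 (0.35 log units; beyond the scatter), is a modest one that concerns a different exchange on a different core and gave no measure of what happens here. No measurement at hand bears on the reason for the step.

From the compounds shown here alone, with only methoxy and fluoro compared at this position on this core, it remains open whether the number depends on keeping an oxygen-linked group there, which ethoxy or hydroxy would test, or whether chloro or a dimethylamino group could match compound 1. Going by these compounds, it also remains open whether the same exchange from 4-methoxyphenyl to 4-fluorophenyl would give a step of similar size on the core shared by compound 2 and compound 3.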